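The compounds below may be only part of what the source reports. "The series", "measured", "known", "first", "only" and "open" are said of these compounds alone.

Results in a functional assay on HCT-15 cells (Homo sapiens) for antiproliferative activity, read by MTT assay, with a stated time of 72 h; a higher number here means a weaker inhibitor, a lower number a stronger inhibitor:

- Compound 1 `COc1cc(-c2nccn2C(C)C)cc(OC)c1OC`: > 100000 nM (a limit, not a number)
- Compound 2 `CCCCCn1ccnc1-c1cc(OC)c(OC)c(OC)c1`: > 100000 nM (a limit, not a number)
- Compound 3 `COc1cc(-c2nccn2-c2ccc(C)cc2)cc(OC)c1OC`: 800 nM

Compound 3 is the only one of the three with a true number, at 800 nM. The other two results sit at the limit of > 100000 nM in this assay, at which 2 of the 3 values shown sit. On these numbers, compound 3 is the most potent of the three in this assay.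

The next compound, compound 4 `COc1cc(-c2nccn2-c2ccc(Br)cc2)cc(OC)c1OC`, keeps everything except one small group, turning 4-methylphenyl into 4-bromophenyl: bromo in place of methyl on an aromatic carbon.

Going by the values given here, two measured steps bear on this only indirectly. They are an at least 120-fold lower number from compound 1 to compound 3 (2.09 log units; beyond the scatter) and an at least 120-fold lower number from compound 2 to compound 3 (2.09 log units; beyond the scatter), both large. Each swaps the entire group on the aromatic nitrogen, showing that 4-methylphenyl there gives measurable activity where isopropyl and pentyl do not. Among the compounds with values here, compound 4 keeps a phenyl ring at that nitrogen, and no measured step changes the group on that ring.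

No shift beyond the scatter is therefore expected, though the uncertainty is wide. The expected step is no change at the digits printed from compound 3 to compound 4 (within the scatter). The estimated value for compound 4 is 800 nM, within an expected range of 150 nM to 4000 nM.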

Compound 4, half-maximal inhibitory concentration: 11700 nM
Compound 4: middle estimate off by 15-fold (1.17 log units), on the low side; the whole stated range lies below it.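

Exchanging methyl for bromo swaps one heavy atom for one heavy atom on the ring carbon para to a large group, yet in this assay it gives a 15-fold higher number from compound 3 to compound 4 (1.17 log units; beyond the scatter), so activity depends on more than having a phenyl ring on the aromatic nitrogen. The 4-bromophenyl group still outperforms the two groups it can be compared with, giving an at least 8.5-fold lower number from compound 2 to compound 4 (0.93 log units; beyond the scatter) and an at least 8.5-fold lower number from compound 1 to compound 4 (0.93 log units; beyond the scatter). Those two steps are open-ended and rest on a limit, not a number: the limit of > 100000 nM in this assay, at which 2 of the 4 values shown sit.

How a fluoro, methoxy or amino group would read on that same ring carbon remains open, as the compounds shown carry methyl or bromo there. Why bromo reads weaker than methyl also remains open.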